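Swapping the Amine on the Aniline of Compound 3

This account rests on a few compounds, and the source may have more. Where it says the series, first, only, none or still open, it means among the compounds named here.

Compound 1 `CCCN(CCC)c1ccc(Nc2ncc(Cl)c(Oc3cccc(NC(=O)CC)c3)n2)cc1`: 9.3%
Compound 2 `CCC(=O)Nc1cccc(Oc2nc(Nc3ccc(N4CCC(OC)CC4)cc3OC)ncc2Cl)c1`: 5.08%
Compound 3 `CCC(=O)Nc1cccc(Oc2nc(Nc3ccc(N4CCCC4)cc3OC)ncc2Cl)c1`: 25.8%

In an assay on isolated protein for inhibition of NUAK family SNF1-like kinase 1 (Homo sapiens), read by ADP-Glo, with a stated time of 60 min, tested at 10 uM, in the presence of a further agent that is not named here (a lower number here means less inhibition, a higher number more inhibition at the concentration tested (going by the name of the read-out)), compound 3 gives the highest of the three numbers; compound 1 and compound 2 both stand lower, and each of those gaps lies beyond the scatter. Compound 4 `CCCN(CCC)c1ccc(Nc2ncc(Cl)c(Oc3cccc(NC(=O)CC)c3)n2)c(OC)c1` differs from compound 3 in one place: dipropylamino in place of pyrrolidin-1-yl on an aromatic carbon. Going by the values given here, the only measured step at this site is a number 20.7 percentage points higher from compound 2 to compound 3 (beyond the scatter), showing that the amine here can shift the read-out by a modest amount. Among the compounds with values here, no measured step joins pyrrolidin-1-yl to dipropylamino directly; compound 1, which carries dipropylamino but no methoxy group, gives 9.3%. The step to compound 4 is therefore expected to be a number 10.8 percentage points lower from compound 3 to compound 4 (beyond the scatter). Compound 4 is estimated at 15%, within a range from 3% to 30%.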

Compound 4, a percentage reported as inhibition, at one concentration (the size of the read-out at that concentration, not a potency): "not active" (no number reported)
For compound 4 the study gives words and no number; no gap can be computed for the estimate.
By their numbers in this assay, from the lowest: compounds 2 and 1 (each within the scatter of the next); then compound 3.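

In this assay, going by these compounds alone, compound 4 is reported as "not active" (no number reported) with no number, so no step from compound 3 can be read. How dipropylamino compares with pyrrolidin-1-yl stays open, and no measurement shown here offers an explanation.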